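A few compounds are considered here, and "the series" means these few. Any claim that something is new, unique, unknown or untested is made for them only; others in the source may bear on it.

Measured compounds in the series:

Compound 1, `Cc1cc(-c2ccc(=O)n(C)c2)cc2cn(C3CCNCC3)nc12`, in an assay on cells for displacement of a labelled ligand from Toll-like receptor 8 (Homo sapiens), read by TR-FRET, with a stated time of 30 min (a higher number here means a weaker inhibitor, a lower number a stronger inhibitor), compound 1 gives 7600 nM.
Compound 2, `Cc1cc(-c2ccc(=O)n(C)c2F)cc2cn(C3CCNCC3)nc12`, in this assay compound 2 gives 800 nM.

Going by the values given here, compound 2 holds the lower of the two numbers measured so far; its nearest neighbour is compound 1, and the step of a 9.5-fold lower number from compound 1 to compound 2 (0.98 log units; beyond the scatter) lies beyond the scatter. That single step is the only one recorded, and it concerns the same aromatic carbon that is varied next.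

Compound 3, `Cc1cc(-c2ccc(=O)n(C)c2Cl)cc2cn(C3CCNCC3)nc12`, differs from compound 2 by chloro in place of fluoro on an aromatic carbon. Among the compounds with values here, no measured pair shows a chloro-for-fluoro exchange, so the step from compound 2 to compound 3 cannot be read off directly; the step of a 9.5-fold lower number from compound 1 to compound 2 (0.98 log units; beyond the scatter) only shows that substitution at this carbon shifts the number considerably. Compound 3 is therefore expected to stay near compound 2, with a wide range: a 1.3-fold lower number from compound 2 to compound 3 (0.12 log units; within the scatter) is the estimated step, giving an expected 600 nM for compound 3, between 150 nM and 2500 nM.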

Compound 3, half-maximal inhibitory concentration: 2100 nM
For compound 3 the middle estimate is 3.5-fold (0.54 log units) below the measured one, and the stated range covers the measured number.
By their numbers in this assay, from the lowest: compound 2; then compound 3; then compound 1.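

In this assay the two halogens on this aromatic carbon are not interchangeable: the exchange of fluoro for chloro gives a step beyond the scatter (a 2.6-fold higher number from compound 2 to compound 3 (0.42 log units; beyond the scatter)). Chloro still retains part of the gain over hydrogen (a 3.6-fold lower number from compound 1 to compound 3 (0.56 log units; beyond the scatter)), so the numbers at this carbon run from fluoro through chloro to hydrogen, lowest to highest. Nothing available accounts for this order.

From the compounds shown here alone, whether bromo, a methyl, a methoxy or a nitrile on this carbon would give a number below that of fluoro or above that of hydrogen remains open. Also open, going by these compounds, is whether the order among fluoro, chloro and hydrogen holds when the methyl group or the amide methyl of the shared core is replaced by another group.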